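The source may report more compounds than this note shows. Statements on the series, on what has been measured and on what is new or still open speak of the compounds shown alone.

Compound 1 `NC(=S)Nc1cccc(OCCCCCOc2ccccc2)c1` carries the shared core of the series. In an ADME assay on Ava5 cells (Homo sapiens) for cytotoxicity (on this read-out lower numbers stand for higher toxicity in this test and higher numbers for lower toxicity in this test), compound 1 gives only a limit, > 50000 nM. Compound 2 `NC(=S)Nc1cccc(OCCCCCOc2ccc(-n3cccc3)cc2)c1` adds a 1H-pyrrol-1-yl group on an aromatic carbon. In this assay compound 2 likewise gives only a limit, > 50000 nM. Between the two, a step that the two limits leave unreadable from compound 1 to compound 2; both values sit at the limit of > 50000 nM in this assay, at which 2 of the 2 values shown sit. Compound 2 thus stands at a limit in this assay, with no number to place against any other compound.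

Compound 3 `NC(=S)Nc1cccc(OCCCCCOc2ccc(-c3cccs3)cc2)c1` differs from compound 2 in one place: thiophen-2-yl in place of 1H-pyrrol-1-yl on an aromatic carbon. Among the measured compounds shown here, the only measured step bearing on this move, a step that the two limits leave unreadable from compound 1 to compound 2, is unreadable, so nothing in the data sets a size or a direction for the change from compound 2 to compound 3 in this assay; a step beyond the scatter is neither expected nor excluded. Compound 3 is therefore expected to sit near the limit again, at about 60000 nM, with an expected range of 20000 nM to 200000 nM. The expected step from compound 2 to compound 3 is a step that the limit leaves unreadable from compound 2 to compound 3, and the result is most likely to be reported once more only as a limit.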

Compound 3, half-maximal cytotoxic concentration: > 50000 nM
Compound 3: a limit, no number; the forecaster's own chance of this, stated with the estimate: 80%; the middle value lies beyond the limit too.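

In this assay compound 3 gives only a limit, as do compound 1 and compound 2, so no step among these three compounds can be read. Still open, on these data alone, is how far each compound lies beyond that limit, and whether hydrogen, 1H-pyrrol-1-yl or thiophen-2-yl at this place changes the read-out at all.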